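A few compounds are considered here, and "the series" means these few. Any claim that something is new, unique, unknown or untested is made for them only; others in the source may bear on it.

Compound 1 `COc1ccc2c(c1)OC(c1cc(OC)c(OC)c(OC)c1)C(C(=O)O)=C2` carries a free carboxylic acid on the shared core. In a functional assay for inhibition of nuclear factor NF-kappa-B complex (Homo sapiens) (a higher number here means a weaker inhibitor, a lower number a stronger inhibitor), compound 1 gives only a limit of the assay, > 50000 nM. Compound 2 `CCOC(=O)C1=Cc2ccc(OC)cc2OC1c1cc(OC)c(OC)c(OC)c1` is its ethyl ester, and in this assay compound 2 gives 25000 nM. Among the values gathered so far this is the single true number; the remaining entry sits at a limit (the limit of > 50000 nM in this assay, at which 1 of the 2 values shown sits). The step of an at least 2.0-fold lower number from compound 1 to compound 2 (0.30 log units; that floor lies within the scatter) comes from ethyl in place of hydrogen on an oxygen next to a carbonyl group, and its floor does not clear the scatter.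

Compound 3 `COc1ccc2c(c1)OC(c1cc(OC)c(OC)c(OC)c1)C(C(=O)NC(C)C)=C2` differs from compound 2 by isopropylamino in place of ethoxy on a carbonyl carbon. For the measured compounds named here, only the acid-to-ester step bears on it, and that step was small and of a different kind; no measured pair trades an ethoxy for an amino group on the carbonyl carbon. The step expected from compound 2 to compound 3, no change at the digits printed from compound 2 to compound 3 (within the scatter), is therefore of no firm direction beyond the scatter, with a real chance that compound 3 returns only a limit. Compound 3 is estimated at 25000 nM, in a range from 6000 nM to 80000 nM.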

Compound 3, half-maximal inhibitory concentration: > 50000 nM
Compound 3 was reported as a limit (the forecaster's own chance of this, stated with the estimate: 40%); middle value at least 2.0-fold (0.30 log units) away from the limit.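

For the compounds shown here, the first change to leave the ester on this carbonyl carbon, isopropylamino in place of ethoxy, gives an at least 2.0-fold higher number from compound 2 to compound 3 (0.30 log units; that floor lies within the scatter), so the result gives no firm sign that the amide differs from the ester in this assay. The result does show that compound 2 is the only one of the three with a true number, while the hydroxy of compound 1 and the isopropylamino of compound 3 both end at a limit of the assay: the limit of > 50000 nM in this assay, at which 2 of the 3 values shown sit. Going by these compounds alone, compound 1 and compound 3 therefore cannot be read against each other, and neither can be told apart from compound 2 beyond the scatter, so the series so far offers only a weak hint that ethoxy is preferred at this place.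

What the compounds shown leave open is how far compound 3 really lies from compound 2, and whether any group on this carbonyl carbon can give a clearly lower number. A longer chain on the ester oxygen, such as butoxy, or a smaller amide group, such as methylamino or dimethylamino, would bear directly on both questions.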